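The source may report more compounds than this note shows. Statements on the series, on what has been measured and on what is new or still open speak of the compounds shown alone.

Going by the values given here, compound 2 `COc1ncc(-c2ccc3c(c2)N(C2CCCCC2)C(=O)CO3)cc1NS(=O)(=O)c1ccc(F)cc1` gives 24600 nM in a functional assay on A549 cells (Homo sapiens) for antiproliferative activity, read by MTT assay, with a stated time of 72 h (a higher number here means a weaker inhibitor, a lower number a stronger inhibitor), the highest of the two numbers in hand; compound 1 `COc1ncc(-c2ccc3c(c2)N(c2ccc(Cl)cc2)C(=O)CO3)cc1NS(=O)(=O)c1ccc(F)cc1` gives 8350 nM, and the only step so far, a 2.9-fold higher number from compound 1 to compound 2 (0.47 log units; beyond the scatter), came from cyclohexyl in place of 4-chlorophenyl on an amide-type nitrogen in a ring. Compound 3 `COc1ncc(-c2ccc3c(c2)N(C(C)C)C(=O)CO3)cc1NS(=O)(=O)c1ccc(F)cc1` carries a further change at the same place, (isopropyl in place of cyclohexyl on an amide-type nitrogen in a ring). Among the compounds with values here, no measured step covers a cyclohexyl to isopropyl swap, so the one step in hand bears on it only loosely. A step no larger than the scatter, in either direction, is expected, giving a 1.1-fold higher number from compound 2 to compound 3 (0.02 log units; within the scatter). Compound 3 is expected at 26000 nM, between 10000 nM and 65000 nM.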

Compound 3, half-maximal inhibitory concentration: 4920 nM
The estimate for compound 3 lay 5.3-fold (0.72 log units) above the measured number; measured number outside the range, below it.
By their numbers in this assay, from the lowest: compounds 3 and 1 (each within the scatter of the next); then compound 2.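

In this assay, isopropyl in place of cyclohexyl on the amide-type nitrogen gives a 5.0-fold lower number from compound 2 to compound 3 (0.70 log units; beyond the scatter), so this position distinguishes between these two carbon-only groups, and cyclohexyl is the outlier of the three. Isopropyl in place of 4-chlorophenyl gives a 1.7-fold lower number from compound 1 to compound 3 (0.23 log units; within the scatter), so a group with no ring on this nitrogen matches the 4-chlorophenyl compound within the scatter. No supporting data explain the difference between these groups. Still open, going by these compounds, is how a methyl group, or a chain ending in an amine, would fare on this nitrogen.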